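The source may hold more compounds than are shown below. What is called first, only, known or untested is meant among the compounds shown, and "the series" means these compounds.

In a functional assay on HT-29 cells (Homo sapiens) for antiproliferative activity, read by sulforhodamine B assay, with a stated time of 48 h (a higher number here means a weaker inhibitor, a lower number a stronger inhibitor), compound 1 `Cc1ccc(OS(=O)(=O)c2ccc(N3CCN(C)C3=O)cc2)c(C)c1` gives 3000 nM. For compound 2 `CCCN1CCN(c2ccc(S(=O)(=O)Oc3ccccc3OC)cc2)C1=O`, the same assay reports > 100000 nM, which is a limit and not a number. Compound 2 therefore offers no exact starting point on the scale.

The next compound to be tested, compound 3 `CCCN1CCN(c2ccc(S(=O)(=O)Oc3ccc(C)cc3C)cc2)C1=O`, carries 2,4-dimethylphenyl in place of 2-methoxyphenyl on an oxygen. Among the compounds with values here, the incoming 2,4-dimethylphenyl group is also present in compound 1, the only compound here with a measured number, at 3000 nM. On that single comparison, a large change toward stronger inhibition is expected in this assay, well beyond the usual scatter, though the evidence is thin and the true size of the change cannot be fixed from a limit. The expected change is an at least 25-fold lower number from compound 2 to compound 3 (1.39 log units; beyond the scatter), and this is an estimate. For compound 3 the estimated half-maximal inhibitory concentration is 4000 nM, with an expected range from 700 nM to 30000 nM.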

Compound 3, half-maximal inhibitory concentration: 26000 nM
For compound 3 the middle estimate is 6.5-fold (0.81 log units) below the measured one; measured number inside the range.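

In this assay, the group on the oxygen bound to the sulfonyl sulfur clearly matters: 2,4-dimethylphenyl in place of 2-methoxyphenyl gives an at least 3.8-fold lower number from compound 2 to compound 3 (0.58 log units; beyond the scatter). Compound 2 stands at a limit and not at a number, so this step has a floor but no fixed size: the limit of > 100000 nM in this assay, at which 1 of the 3 values shown sits. With 2,4-dimethylphenyl held constant, the other end of the molecule also counts, as ethyl in place of hydrogen on a saturated chain carbon bound to an amide-type nitrogen in a ring gives an 8.7-fold higher number from compound 1 to compound 3 (0.94 log units; beyond the scatter), so the 2,4-dimethylphenyl group alone does not set the level seen for compound 1.

The compounds shown leave open whether the weakening follows chain length at that carbon, and how a single added methyl group, giving an ethyl chain on the ring nitrogen, or a cyclopropyl group there would read. Also open, going by these compounds, are which of the two methyl groups in 2,4-dimethylphenyl matters, how a 4-chlorophenyl group on the same oxygen would compare, and how 2-methoxyphenyl would read on the core of compound 1.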